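The source may hold more compounds than are shown below. What is called first, only, known or untested is meant among the compounds shown, and "the series" means these compounds.

Measured so far:
- compound 1 `Cc1ccc(C)c(NC(=O)c2ccc(/N=N\c3c[nH]c4ccccc34)cc2)c1`: "not active" (no number reported)
- compound 2 `Cc1cccc(NC(=O)c2ccc(/N=N\c3c[nH]c4ccccc34)cc2)c1`: 300 nM

Two compounds share one core and differ only in the group attached to the amide nitrogen. In a functional assay on P388 cells (Mus musculus) for inhibition, read by MTT assay, with a stated time of 72 h (on this read-out lower numbers stand for stronger inhibition and higher numbers for weaker inhibition), compound 1 is recorded as "not active" (no number reported), with no number behind it, so it stands without a position on the scale. In this assay compound 2 gives 300 nM, a number that places it well within the measurable range. Among the compounds with values here, no step is computed between these two, and their values show only that one was measured and the other was not.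

Compound 3 `O=C(Nc1cccc([N+](=O)[O-])c1)c1ccc(/N=N\c2c[nH]c3ccccc23)cc1` is the next member: 3-nitrophenyl in place of 2,5-dimethylphenyl on an amide-type nitrogen. Because compound 1 stands at "not active" (no number reported), the direction of this change can only be towards stronger inhibition, a lower number, if anything changes at all; its size is an open question. Given that compound 2 gives 300 nM, compound 3 is expected to reach 1500 nM, within a broad range from 150 nM to 15000 nM.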

Compound 3, half-maximal inhibitory concentration: 51900 nM
Compound 3: middle estimate off by 35-fold (1.54 log units), on the low side, outside the stated range (above it).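

In this assay, putting nitro in place of methyl on an aromatic carbon gives a 170-fold higher number from compound 2 to compound 3 (2.24 log units; beyond the scatter), so a single replacement on the group carried by the amide nitrogen can move a compound far along the scale. The earlier compounds shown here could not show this, since compound 1 has no number and the step from it to compound 3 cannot be read. Why nitro has such a large effect here is not explained by any measurement available.

As far as these compounds go, it remains open whether an amine or a carboxylic acid in place of that methyl would keep the value close to that of compound 2 (300 nM). Also open, from the compounds shown here alone, is whether the methyl itself matters, which a plain unsubstituted phenyl group would test.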